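From compound 3 to compound 4: one added methoxy

The compounds below may be only part of what the source reports. "The series", "measured", "known", "first", "only" and "open" are said of these compounds alone.

Compound 1 `COc1ccc(/C=C/C(=O)/C(C)=C/c2ccccc2)cc1` gives 51000 nM
Compound 2 `COc1ccc(/C=C/C(=O)/C(C)=C/c2ccc(OC)cc2)cc1` gives 34100 nM
Compound 3 `C/C(=C\c1ccc([N+](=O)[O-])cc1)C(=O)/C=C/c1ccccc1` gives 47300 nM

In an ADME assay on J774.A1 cells (Mus musculus) for cytotoxicity, read by MTT assay, with a stated time of 48 h (on this read-out lower numbers stand for higher toxicity in this test and higher numbers for lower toxicity in this test), these three compounds sit close together, and compound 3 lies within the scatter of both compound 1 and compound 2. Compound 4 `COc1ccc(/C=C/C(=O)/C(C)=C/c2ccc([N+](=O)[O-])cc2)cc1` is compound 3 with methoxy in place of hydrogen on an aromatic carbon. For the measured compounds named here, one measured step bears on this, since it is the same exchange: a 1.5-fold lower number from compound 1 to compound 2 (0.17 log units; within the scatter). That is a single step and it stays within the scatter. The step expected in this assay is therefore small and no larger than the scatter, estimated as a 1.2-fold lower number from compound 3 to compound 4 (0.10 log units; within the scatter). For compound 4 the estimated value is 38000 nM, with an expected range from 22000 nM to 65000 nM.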

Compound 4, half-maximal cytotoxic concentration: 36600 nM
Compound 4: middle estimate off by 1.0-fold (0.02 log units), on the high side, and the stated range covers the measured number.
By their numbers in this assay, from the lowest: compounds 2, 4, 3 and 1 (each within the scatter of the next).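

In this assay, methoxy in place of hydrogen on an aromatic carbon, para to a large group, now reads on a second core, giving a 1.3-fold lower number from compound 3 to compound 4 (0.11 log units; within the scatter). Nitro at the same place gives a 1.1-fold higher number from compound 2 to compound 4 (0.03 log units; within the scatter) against methoxy and a 1.4-fold lower number from compound 1 to compound 4 (0.14 log units; within the scatter) against hydrogen, so hydrogen, methoxy and nitro are not told apart here. The methoxy step is of similar size on both cores: the same change on two cores in this assay, a 1.5-fold lower number (0.17 log units; within the scatter) from compound 1 to compound 2 and a 1.3-fold lower number (0.11 log units; within the scatter) from compound 3 to compound 4, 1.2-fold (0.06 log units) apart, within the scatter of two such steps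

On these data alone, whether an amine or a carboxylic acid at this place would move the number beyond the scatter stays open.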